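Swapping cyclohexyl for 2,2,2-trifluoroethyl on a level baseline

The source may hold more compounds than are shown below. What is called first, only, known or untested is meant among the compounds shown, and "the series" means these compounds.

In a physicochemical assay for solubility, at pH 1.1 (a lower number here means a less soluble compound, a higher number a more soluble compound), compound 1 `CCCN(Cc1ccc(OCCN2C(=O)CCC2=O)c(C)c1)C(CC(=O)O)c1ccc(Cl)cc1` gives 3000000 nM and compound 2 `Cc1cc(CN(CC2CCCCC2)C(CC(=O)O)c2ccc(Cl)cc2)ccc1OCCN1C(=O)CCC1=O` gives 3000000 nM as well, so compound 2 stands level with compound 1 at the digits reported. Compound 3 `Cc1cc(CN(CCC(F)(F)F)C(CC(=O)O)c2ccc(Cl)cc2)ccc1OCCN1C(=O)CCC1=O` departs from compound 2 by 2,2,2-trifluoroethyl in place of cyclohexyl on a saturated chain carbon bound to an amine nitrogen in its structure: 2,2,2-trifluoroethyl in place of cyclohexyl on a saturated chain carbon bound to an amine nitrogen. Among the measured compounds shown here, the only measured step at this place is no change at the digits printed from compound 1 to compound 2 (within the scatter) and it concerns another pair of groups, ethyl and cyclohexyl. That single step gives no direction to follow, so no move beyond the scatter is expected in this assay for the new group. The expected change is no change at the digits printed from compound 2 to compound 3 (within the scatter) on this estimate. Compound 3 is estimated at 3000000 nM within an expected range from 1500000 nM to 4000000 nM in this measurement.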

Compound 3, solubility: 3000000 nM
Compound 3: middle estimate and measured number agree at the digits printed, within the range that was stated.
By their numbers in this assay, from the lowest: compounds 1, 2 and 3 (each within the scatter of the next).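

In this assay the read-out shows no change at the digits printed from compound 2 to compound 3 (within the scatter), and it shows no change at the digits printed from compound 1 to compound 3 (within the scatter). Until now this place had carried only all-carbon groups, ethyl and cyclohexyl; 2,2,2-trifluoroethyl brings in fluorine and no ring, and compound 3 still reads 3000000 nM, so the level reading at this place now holds for a group that is not carbon alone. No information is available that would account for this level reading.

The three compounds leave open whether a group carrying nitrogen or oxygen at this place, such as a primary amine or a carboxylic acid, would also leave the number level. They also say nothing about whether the same swap would read the same on a core with the chlorine or the succinimide changed.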